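Swapping a Methyl for Oxan-4-yl on a Shared Core

The compounds below may be only part of what the source reports. "The series", "measured", "known", "first", "only" and "open" are said of these compounds alone.

In an ADME assay on Caco-2 cells (Homo sapiens) for permeability, in the apical to basolateral direction (a lower number here means that the compound crosses the layer more slowly, a higher number that the compound crosses the layer faster), compound 1 (`COC(=O)N1CCN([C@H]2CC[C@H](Nc3ncnn4ccc([C@H](C)CC(=O)N(C)C)c34)CC2)CC1`) gives 18 10^-6 cm/s as its reading, and compound 2 (`Cc1ccn2ncnc(N[C@H]3CC[C@H](N(C)C)CC3)c12`) gives 36 10^-6 cm/s as its reading. Among the compounds with values here, these values lie within the usual scatter of repeated measurements, so compound 2 stands level with compound 1 on the numbers so far.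

The next structure, compound 3 (`CN(C)[C@H]1CC[C@H](Nc2ncnn3ccc(C4CCOCC4)c23)CC1`), has oxan-4-yl in place of methyl on an aromatic carbon of compound 2 (oxan-4-yl in place of methyl on an aromatic carbon) and is otherwise the same. Within the data shown here, no measured pair of compounds shows this swap on its own, so there is no direct precedent for its size. Among the measured compounds shown here, the only other guide is compound 1, at 18 10^-6 cm/s in the same measurement. On that thin basis, a modest downward move is expected, one that would probably stay within the scatter. The estimated change is a 1.5-fold lower number from compound 2 to compound 3 (0.18 log units; within the scatter) in this assay readings. For compound 3 the expected value is 24 10^-6 cm/s with a likely range of 10 10^-6 cm/s to 45 10^-6 cm/s in this assay readings.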

Compound 3, apparent permeability: 14 10^-6 cm/s
Estimate against measurement, compound 3: 1.7-fold (0.23 log units) above; low and high end bracket the measured number.
By their numbers in this assay, from the lowest: compounds 3, 1 and 2 (each within the scatter of the next, the first and the last beyond it).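

Putting oxan-4-yl in place of methyl on an aromatic carbon of the five-membered aromatic ring gives, in this assay, a 2.6-fold lower number from compound 2 to compound 3 (0.41 log units; beyond the scatter), so the reading at this position changes with the group it carries. Within the data shown here, this is the first comparison here in which only one place differs, whereas compound 1 and compound 2 differ in more than one place and so could not isolate any single change. No measurement here accounts for the lower number, so the step stands as an observation without an explanation.

A single step cannot separate the parts of this swap, since oxan-4-yl brings a ring, an oxygen atom and more heavy atoms all at once, and the step comes from one pair on one shared core. Cyclohexyl, the same kind of six-membered ring with carbon in place of the oxygen, would set the oxygen apart from the ring, while an open propyl chain would set the ring apart from the added carbons.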